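Compound 1 and a methyl on its core

The source may report more compounds than this note shows. Statements on the series, on what has been measured and on what is new or still open speak of the compounds shown alone.

Compound 1 `c1ccc(-c2nnc(-c3cn4ccccc4n3)o2)cc1`: 23400 nM
Compound 2 `Clc1ccc(-c2nnc(-c3cn4ccccc4n3)o2)cc1`: 32400 nM
Compound 3 `Brc1ccc(-c2nnc(-c3cn4ccccc4n3)o2)cc1`: > 50000 nM

Within the data shown here, in a functional assay on A549 cells (Homo sapiens) for antiproliferative activity, read by MTT assay, with a stated time of 48 h (on this read-out lower numbers stand for stronger inhibition and higher numbers for weaker inhibition), compound 1 gives 23400 nM, and no measured compound shows a clearly lower number. Compound 3 stands at > 50000 nM, which is a limit of the assay and not a number.

Compound 4 `Cc1cccn2cc(-c3nnc(-c4ccccc4)o3)nc12` has not yet been measured. It carries methyl in place of hydrogen on an aromatic carbon of the core of compound 1 : methyl in place of hydrogen on an aromatic carbon. The measured steps that bear on this change put chloro in place of hydrogen, a 1.4-fold higher number from compound 1 to compound 2 (0.14 log units; within the scatter), and bromo in place of hydrogen, an at least 2.1-fold higher number from compound 1 to compound 3 (0.32 log units; beyond the scatter). Neither step introduces a methyl, and neither falls on the ring that takes it, so they offer only a loose guide. The chloro step stays within the scatter and the bromo step is modest, so no step beyond the scatter is expected in this assay. The expected step is a 1.1-fold lower number from compound 1 to compound 4 (0.03 log units; within the scatter). Compound 4 is estimated at 22000 nM, with an expected range from 9000 nM to 50000 nM.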

Compound 4, half-maximal inhibitory concentration: 23400 nM
For compound 4 the middle estimate is 1.1-fold (0.03 log units) below the measured one, within the range that was stated.
By their numbers in this assay, from the lowest: compounds 1, 4 and 2 (each within the scatter of the next). At a limit, above all of these: compound 3.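

With methyl in place of hydrogen on an aromatic carbon of the six-membered aromatic ring with 1 nitrogen, this assay shows no change at the digits printed from compound 1 to compound 4 (within the scatter) and so this position of the core takes a methyl without a step beyond the scatter. The chloro and bromo steps fall on a different ring, which makes this the only reading shown for a change on the core itself. Nothing given here accounts for this flat step.

Going by these compounds, whether an ethyl, an amine or a carboxylic acid on this same carbon would leave the number equally in place remains open. Also open, on these data alone, is what a methyl would do on the other aromatic carbons of the core, or together with the chloro of compound 2.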